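Hydroxyphenyl shift on the shared core toward compound 4

A few compounds are considered here, and "the series" means these few. Any claim that something is new, unique, unknown or untested is made for them only; others in the source may bear on it.

Compound 2 `Oc1ccc(-c2cc(-c3ccccc3F)cc(-c3ccccc3O)n2)cc1` is the reference point. In a functional assay on HCT-15 cells (Homo sapiens) for inhibition (a lower number here means a stronger inhibitor, a higher number a weaker inhibitor), compound 2 gives only a limit, > 50000 nM. Compound 1 `Oc1ccccc1-c1cc(-c2ccccc2F)cc(-c2ccccc2O)n1` is likewise held at a limit in this assay, > 50000 nM. Compound 3 `Oc1ccc(-c2cc(-c3cccc(F)c3)cc(-c3ccccc3O)n2)cc1` also sits at a limit in this assay, > 50000 nM. the limit of > 50000 nM in this assay, at which 3 of the 3 values shown sit: every value in the set rests on that limit, so compound 2 cannot be placed relative to the others beyond it.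

The change to compound 4 `Oc1ccc(-c2cc(-c3ccccc3F)cc(-c3cccc(O)c3)n2)cc1` is 3-hydroxyphenyl in place of 2-hydroxyphenyl on an aromatic carbon. Among the measured compounds shown here, two measured steps touch other rings of the same core. The step that the two limits leave unreadable from compound 1 to compound 2 moves the hydroxyl around one ring, and the step that the two limits leave unreadable from compound 2 to compound 3 moves the fluorine around another; both have unreadable sizes, their ends sitting at the limit. For the measured compounds named here, no measured step bears directly on the hydroxyphenyl that changes here, and nothing in the set gives a numerical size to a shift of this kind. The step that the limit leaves unreadable from compound 2 to compound 4 is therefore expected to be unreadable as well, with no movement beyond the scatter that the data could reveal. Compound 4 is estimated at 60000 nM in this assay, in the range 20000 nM to 200000 nM.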

Compound 4, half-maximal inhibitory concentration: 5630 nM
Compound 4: the middle estimate sits 11-fold (1.03 log units) above what was measured, and the stated range ends above it.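

In this assay, putting 3-hydroxyphenyl in place of 2-hydroxyphenyl on the aromatic carbon next to the ring nitrogen gives an at least 8.8-fold lower number from compound 2 to compound 4 (0.94 log units; beyond the scatter), so the placing of the hydroxyl on this ring has a readable effect on the number, even though the leaving and entering groups count the same heavy atoms, donors and acceptors. Among the compounds shown here, the other steps in the set cannot be read, and this one is the first to show that the series can move in this assay at all, with compounds 1, 2 and 3 all still carrying 2-hydroxyphenyl at this place and compound 4 alone carrying 3-hydroxyphenyl there. Compound 4 is also the only compound in the set with a number rather than a limit, which leaves its step as a minimum size and not a full one: the limit of > 50000 nM in this assay, at which 3 of the 4 values shown sit.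

The compounds shown leave open whether the gain needs the hydroxyl itself or would survive an amine or a carboxylic acid at the same ring place. They also leave open whether 3-hydroxyphenyl at this place keeps its effect alongside 3-fluorophenyl, or with the 4-hydroxyphenyl group changed.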